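Hydrazone series on liver cells: compound 1 toward compound 4

A few compounds are considered here, and "the series" means these few. Any claim that something is new, unique, unknown or untested is made for them only; others in the source may bear on it.

Measured compounds:
compound 1 `Cc1nc(N(C)C(=O)NC(=O)c2c(F)cccc2F)sc1C(=O)N/N=C/c1ccccc1F`: > 100 ug/mL
compound 2 `CN(C(=O)NC(=O)c1ccc(C(F)(F)F)cc1)c1nc(C(F)(F)F)c(C(=O)N/N=C/c2ccc(C(F)(F)F)cc2)s1`: > 100 ug/mL
compound 3 `CN(C(=O)NC(=O)c1ccc(F)c(F)c1)c1nc(C(F)(F)F)c(C(=O)N/N=C/c2cccc(C(F)(F)F)c2)s1`: 5.6 ug/mL

In a functional assay on HepG2 cells (Homo sapiens) for inhibition, read by MTT assay, with a stated time of 72 h (on this read-out lower numbers stand for stronger inhibition and higher numbers for weaker inhibition), compound 1 gives > 100 ug/mL, which is a limit of the assay and not a number. Compound 1 therefore stands at the limit of > 100 ug/mL in this assay, at which 2 of the 3 values shown sit. Compound 2 likewise gives only a limit, > 100 ug/mL. Among the compounds with values here, compound 3 gives 5.6 ug/mL, the single number in this assay so far.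

Compound 4 `COc1cc(/C=N/NC(=O)c2sc(N(C)C(=O)NC(=O)c3c(F)cccc3F)nc2C)cc(OC)c1OC` is not yet measured. It differs from compound 1 in one place: 3,4,5-trimethoxyphenyl in place of 2-fluorophenyl on a carbon with a double bond to nitrogen. Within the data shown here, no measured pair of compounds shows this change, so its size and direction cannot be read from the data. Compound 4 is expected to give 60 ug/mL, with a range from 15 ug/mL to 200 ug/mL. The step of an at least 1.6-fold lower number from compound 1 to compound 4 (0.22 log units; that floor lies within the scatter) is an estimate only, and a further limit remains possible.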

Compound 4, half-maximal inhibitory concentration: > 100 ug/mL
Compound 4: no number, only a limit; the forecaster's own chance of this, stated with the estimate: 50%; middle value at least 1.6-fold (0.22 log units) away from the limit.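

Compound 1 and compound 4 each give only a limit of the assay, not a number, and no step can be read between them. From the compounds shown here alone, whether 3,4,5-trimethoxyphenyl in place of 2-fluorophenyl changes the read-out at all stays open.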